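The source may hold more compounds than are shown below. What is called first, only, known or untested is meant among the compounds shown, and "the series" means these compounds.

Measured in a functional assay on MCF7 cells (Homo sapiens) for inhibition, with a stated time of 96 h; a higher number here means a weaker inhibitor, a lower number a stronger inhibitor:

- Compound 1 `COc1cc(C(=O)c2cn(-c3ccc(C)cc3)cc2-c2ccsc2)cc(OC)c1OC`: 4 nM
- Compound 2 `COc1cc(C(=O)c2cn(-c3ccc(C)cc3)cc2-c2ccoc2)cc(OC)c1OC`: 18 nM
- Compound 3 `COc1cc(C(=O)c2cn(-c3ccc(C)cc3)cc2-c2ccccn2)cc(OC)c1OC`: 36 nM

Compound 3 shares the high end of these numbers with compound 2: there is a 2.0-fold higher number from compound 2 to compound 3 (0.30 log units; within the scatter), but there is a 9.0-fold higher number from compound 1 to compound 3 (0.95 log units; beyond the scatter). Compound 4 `COc1cc(C(=O)c2cn(-c3ccc(C)cc3)cc2-c2cccnc2)cc(OC)c1OC` has pyridin-3-yl in place of pyridin-2-yl on an aromatic carbon. Going by the values given here, no measured step makes this exact swap. The steps at the same place are modest at most, with a 4.5-fold higher number from compound 1 to compound 2 (0.65 log units; beyond the scatter) alongside the two above. The two compounds without thiophen-3-yl stay within the scatter of each other, so no step beyond the scatter is expected here. The expected change is a 1.3-fold lower number from compound 3 to compound 4 (0.11 log units; within the scatter). For compound 4 the estimated value is 28 nM, with an expected range of 9 nM to 85 nM.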

Compound 4, half-maximal inhibitory concentration: 19 nM
Estimate against measurement, compound 4: 1.5-fold (0.17 log units) above; low and high end bracket the measured number.
By their numbers in this assay, from the lowest: compound 1; then compounds 2, 4 and 3 (each within the scatter of the next).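

Moving the ring nitrogen, with the same atoms joined differently, gives a 1.9-fold lower number from compound 3 to compound 4 (0.28 log units; within the scatter), so at this position pyridin-3-yl and pyridin-2-yl cannot be told apart. Against the furan-3-yl group there is a 1.1-fold higher number from compound 2 to compound 4 (0.02 log units; within the scatter), whereas thiophen-3-yl remains apart, with a 4.8-fold higher number from compound 1 to compound 4 (0.68 log units; beyond the scatter). No measurement shown here explains why thiophen-3-yl stands apart.

From the compounds shown here alone, whether pyridin-4-yl, thiophen-2-yl or a plain phenyl group at this position would match compound 1 or the other three remains open.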